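From a Dimethylamino Chain to a 4-Methoxybenzyl Group

A few compounds are considered here, and "the series" means these few. Any claim that something is new, unique, unknown or untested is made for them only; others in the source may bear on it.

Measured in a functional assay on HCT-116 cells (Homo sapiens) for cytotoxicity, read by fluorescence, with a stated time of 72 h; on this read-out lower numbers stand for stronger inhibition and higher numbers for weaker inhibition:
- compound 1 `CC(C)c1n[nH]c2c(NCc3ccc(-c4ccccn4)cc3)nc(NCCO)nc12`: 27 nM
- compound 2 `CC(C)c1n[nH]c2c(NCc3ccc(-c4ccccn4)cc3)nc(NCCN)nc12`: 227 nM
- compound 3 `CC(C)c1n[nH]c2c(NCc3ccc(-c4ccccn4)cc3)nc(NCCN(C)C)nc12`: 390 nM

Compound 3, at 390 nM, stands with compound 2 at the upper end of these numbers. The two are separated only by a 1.7-fold higher number from compound 2 to compound 3 (0.24 log units; within the scatter). The gap to the hydroxy compound is much wider, at a 14-fold higher number from compound 1 to compound 3 (1.16 log units; beyond the scatter).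

The next compound, compound 4 `COc1ccc(CNc2nc(NCc3ccc(-c4ccccn4)cc3)c3[nH]nc(C(C)C)c3n2)cc1`, has not yet been measured. It differs from compound 3 by 4-methoxyphenyl in place of (dimethylamino)methyl on a saturated chain carbon bound to a nitrogen on an aromatic ring, which is 4-methoxyphenyl in place of (dimethylamino)methyl on a saturated chain carbon bound to a nitrogen on an aromatic ring.

All three measured steps fall at this same chain end. Alongside the wide gap above, an 8.4-fold higher number from compound 1 to compound 2 (0.92 log units; beyond the scatter) shows that changes here can move the number well beyond the scatter. Within the data shown here, no measured compound carries an aromatic ring at this place, so these steps give a scale rather than a direct precedent. Compound 4 lacks the dimethylamino group, as does compound 1 at 27 nM, so a partial move toward that value is expected, with wide uncertainty. The expected change is modest, a 2.6-fold lower number from compound 3 to compound 4 (0.41 log units; beyond the scatter). For compound 4 in this assay, the estimated value is 150 nM, with an expected range of 35 nM to 650 nM.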

Compound 4, half-maximal inhibitory concentration: 17400 nM
Compound 4: the middle estimate sits 120-fold (2.06 log units) below what was measured; the whole stated range lies below it.
By their numbers in this assay, from the lowest: compound 1; then compounds 2 and 3 (each within the scatter of the next); then compound 4.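

In this assay the change to 4-methoxyphenyl on a saturated chain carbon bound to a nitrogen on an aromatic ring gave a 45-fold higher number from compound 3 to compound 4 (1.65 log units; beyond the scatter) and is larger than any step among the earlier compounds, so this place can move the number further than those chain ends had shown. Compound 4 lacks the dimethylamino group yet did not move toward the hydroxy compound, and a 77-fold higher number from compound 2 to compound 4 (1.88 log units; beyond the scatter) and a 640-fold higher number from compound 1 to compound 4 (2.81 log units; beyond the scatter) are both large steps in the same upward direction. Compound 4 is the weakest of the four and the only one here with a six-membered aromatic ring of carbon only at this place, while the hydroxy and amine chain ends all give much lower numbers.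

With a single aromatic example, the compounds shown leave open whether the ring, its methoxy group or the loss of the 2-(dimethylamino)ethyl chain accounts for this step, and an unsubstituted benzyl group, a 4-hydroxybenzyl group or a longer chain such as 3-hydroxypropyl would help separate these. Nothing available here gives a cause for the size of this step.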